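Bicyclic replacement for the pyridine on the urea nitrogen

This account rests on a few compounds, and the source may have more. Where it says the series, first, only, none or still open, it means among the compounds named here.

Measured compounds:
compound 1 `CC(C)n1cnnc1-c1cccc(NC(=O)Nc2ccccn2)n1`: 1090 nM
compound 2 `CC(C)n1cnnc1-c1cccc(NC(=O)Nc2ccc(-c3ccn(C)n3)cn2)n1`: 2780 nM
compound 3 `CC(C)n1cnnc1-c1cccc(NC(=O)Nc2cnc3ccccc3n2)n1`: 4860 nM

All three share one core and differ only in the aromatic group on the urea nitrogen. In an assay on isolated protein for inhibition of mitogen-activated protein kinase kinase kinase 6 (Homo sapiens) (on this read-out lower numbers stand for stronger inhibition and higher numbers for weaker inhibition), compound 1 gives the lowest number of the three. Its nearest neighbour is compound 2, and the step of a 2.6-fold higher number from compound 1 to compound 2 (0.41 log units; beyond the scatter) lies beyond the scatter. Going by the values given here, compound 3, with its fused two-ring group, gives a higher number still, though no single-point step connects it to compound 1.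

Compound 4 `CC(C)n1cnnc1-c1cccc(NC(=O)Nc2cc3ccccn3n2)n1` carries the change (a group of 9 heavy atoms (7 carbon, 2 nitrogen; one five-membered aromatic ring with 2 hetero atoms, one six-membered aromatic ring with 1 hetero atom) in place of a group of 6 heavy atoms (5 carbon, 1 nitrogen; one six-membered aromatic ring with 1 hetero atom), on an amide-type nitrogen). Among the compounds with values here, no measured step covers exactly this swap. Within the data shown here, the one step that bears on it is the modest increase from compound 1 to compound 2 on adding a further ring; the values of compound 1 and compound 3 show that a fused bicyclic group on the same nitrogen also went with a higher number. Growing the group at this position has so far raised the readout each time, so a modest rise in this assay is expected for compound 4, with real uncertainty in its size.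

For compound 4 the estimate is 2500 nM, within a range of 800 nM to 8000 nM, corresponding to an expected step of a 2.3-fold higher number from compound 1 to compound 4 (0.36 log units; beyond the scatter).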

Compound 4, half-maximal inhibitory concentration: 4990 nM
For compound 4 the middle estimate is 2.0-fold (0.30 log units) below the measured one, and the stated range covers the measured number.
By their numbers in this assay, from the lowest: compound 1; then compounds 2, 3 and 4 (each within the scatter of the next).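

In this assay, putting this fused two-ring group in place of pyridin-2-yl on the amide-type nitrogen gives a 4.6-fold higher number from compound 1 to compound 4 (0.66 log units; beyond the scatter). Going by these compounds alone, this is the first direct one-place comparison of a fused two-ring group with pyridin-2-yl at this position, and it shows that such a swap can carry a cost beyond the scatter. Compound 3 and compound 4 carry different fused groups, yet their numbers lie within the scatter of each other, so in these four compounds the higher number does not depend on one particular fused group, and neither compound 2, compound 3 nor compound 4 goes against the trend of larger groups giving a higher number than compound 1, though nothing measured here explains that trend.

The compounds shown leave open whether a single five-membered ring, such as a pyrazolyl group, or a simple methyl on the same nitrogen would give a lower number than compound 1. They also leave open whether a small substituent on the pyridin-2-yl ring, such as a fluorine or a methoxy group, would raise the number as the 1-methyl-1H-pyrazol-3-yl group does.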